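The source may hold more compounds than are shown below. What is called first, only, known or untested is meant among the compounds shown, and "the series" means these compounds.

Compound 1, `Cc1nc(-c2cccnc2)sc1-c1nnc(-c2ccccc2)o1`: in an ADME assay on THP-1 cells (Homo sapiens) for cytotoxicity, read by MTT assay (on this read-out lower numbers stand for higher toxicity in this test and higher numbers for lower toxicity in this test), compound 1 gives > 100 ug/mL, which is a limit of the assay and not a number.
Compound 2, `Cc1nc(-c2cccnc2)sc1-c1nnc(-c2ccccc2[N+](=O)[O-])o1`: in this assay compound 2 gives > 100 ug/mL, again a limit and not a number.

Going by the values given here, compound 1 therefore stands only at a limit; no number for it is known, and the one further value shown is a limit as well. Among the compounds with values here, the single measured step, a step that the two limits leave unreadable from compound 1 to compound 2, is unreadable for the same reason, because of the limit of > 100 ug/mL in this assay, at which 2 of the 2 values shown sit.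

Compound 3, `Cc1cccc(-c2nnc(-c3sc(-c4cccnc4)nc3C)o2)c1`, differs from compound 1 in one place: methyl in place of hydrogen on an aromatic carbon.

The measured step from compound 1 to compound 2 bears on this only loosely, since it concerns a different group, and its size cannot be read. So nothing measured gives a direction or a size for the change to compound 3. The expectation is that compound 3 behaves like compound 1 in this assay, with an estimated step that the limit leaves unreadable from compound 1 to compound 3. Compound 3 is therefore estimated at 150 ug/mL, within the range from 70 ug/mL to 320 ug/mL, most likely reported once more only as a limit.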

Compound 3, half-maximal cytotoxic concentration: > 100 ug/mL
Compound 3: no number, only a limit; the forecaster's own chance of this, stated with the estimate: 85%; the middle value does not contradict the limit.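

No new step can be read between compound 1 and compound 3, because each gives only a limit of the assay and not a number: the limit of > 100 ug/mL in this assay, at which 3 of the 3 values shown sit.

The compounds shown leave open whether methyl, nitro or any other group on the phenyl changes the result in this assay at all, and by how much, since none of them gives a number to compare.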